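This account rests on a few compounds, and the source may have more. Where it says the series, first, only, none or still open, it means among the compounds named here.

Of the compounds shown here, three with a shared core have been measured in a functional assay on Hs-578T cells (Homo sapiens) for cytotoxicity, read by sulforhodamine B assay, with a stated time of 48 h; a higher number here means a weaker inhibitor of growth, a lower number a stronger inhibitor of growth. Compound 1 `ClCc1ccccc1Cn1cnc2c(Cl)nc(Cl)nc21` gives 1170 nM. Compound 2 `ClCc1cccc(Cn2cnc3c(Cl)nc(Cl)nc32)c1` gives 1990 nM; the difference between the cores of compound 1 and compound 2 is not broken down here. Compound 3 `Nc1nc(Cl)c2ncn(Cc3ccccc3CCl)c2n1` gives 7760 nM, a higher number than compound 2 shows.

Compound 3 arises from compound 1 by one change, (amino in place of chloro on an aromatic carbon). That change made a step of a 6.6-fold higher number from compound 1 to compound 3 (0.82 log units; beyond the scatter) in this assay.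

Compound 4 `Nc1nc(Cl)c2ncn(Cc3cccc(CCl)c3)c2n1` has not yet been measured. It arises from compound 2 by the same change, (amino in place of chloro on an aromatic carbon); the place of the change is described in the same words for both pairs, so this is the same change made on the core of compound 2 instead of the core of compound 1.

Among the measured compounds shown here, only one such step has been seen, so the expectation rests on it alone. Because compound 1 moved to compound 3 by a 6.6-fold higher number from compound 1 to compound 3 (0.82 log units; beyond the scatter), compound 4 is expected to move from compound 2 by about a 6.0-fold higher number from compound 2 to compound 4 (0.78 log units; beyond the scatter). Compound 4 is therefore estimated at 12000 nM in this assay, with an expected range from 5000 nM to 30000 nM.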

Compound 4, concentration for 50% growth inhibition: 11500 nM
The estimate for compound 4 lay 1.0-fold (0.02 log units) above the measured number, within the range that was stated.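

In this assay, putting amino in place of chloro on the core of compound 2 gave a 5.8-fold higher number from compound 2 to compound 4 (0.76 log units; beyond the scatter), so the loss of growth inhibition seen on the core of compound 1 appeared again on a second core. The two steps match in size and direction: the same change on two cores in this assay, a 6.6-fold higher number (0.82 log units; beyond the scatter) from compound 1 to compound 3 and a 5.8-fold higher number (0.76 log units; beyond the scatter) from compound 2 to compound 4, 1.1-fold (0.06 log units) apart, within the scatter of two such steps. For these two pairs, then, the size of the step on one core would have served as a fair guide to its size on the other, but two pairs in a single cell assay do not show that the same would hold on a more different core or in other cells, and they do not explain why the number rises.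

The compounds shown leave open how other groups at the same ring carbon, such as a methoxy group or a methylamino group, would compare with amino and chloro. They also leave open whether the step would stay the same if the chloromethyl group were replaced, for example by a hydroxymethyl group.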